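A few compounds are considered here, and "the series" means these few. Any claim that something is new, unique, unknown or untested is made for them only; others in the source may bear on it.

Compound 1 `Cc1c(CN2CCN(c3ccc(N4C[C@H](Cn5cc(-c6ccccn6)nn5)OC4=O)cc3F)CC2)cc(-c2ccc(Cl)c(F)c2)n1-c1ccc(OC(F)(F)F)cc1`: > 40000 nM
Compound 2 `Cc1c(CN2CCN(c3ccc(N4C[C@H](Cn5cc(-c6cncn6C)nn5)OC4=O)cc3F)CC2)cc(-c2ccc(C(C)C)cc2)n1-c1ccc(F)cc1F`: > 40000 nM

Both compounds were tested in an ADME assay on J744 cells (Mus musculus) for inhibition, read by MTT assay, with a stated time of 24 h; a lower number here means a stronger inhibitor, a higher number a weaker inhibitor. For compound 1 the reported result is a limit of the assay rather than a number, > 40000 nM. For compound 2 the result is likewise a limit and not a number, > 40000 nM. Among the compounds with values here, compound 2 therefore stands at the edge of what the assay can report, as does the only other compound measured: the limit of > 40000 nM in this assay, at which 2 of the 2 values shown sit. Nothing here separates the two from each other.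

Compound 3 `CC(=O)NC[C@H]1CN(c2ccc(N3CCN(Cc4cc(-c5ccc(C(C)C)cc5)n(-c5ccc(F)cc5F)c4C)CC3)c(F)c2)C(=O)O1` shares the core of compound 2 and differs from it in one place: acetamido in place of 4-(1-methyl-1H-imidazol-5-yl)-1H-1,2,3-triazol-1-yl on a saturated chain carbon bound to a saturated ring carbon.

Within the data shown here, no measured pair here differs in a single place, so there is no measured step to lean on. Given that compound 2 sits at a limit, no change beyond the scatter of this assay is expected for compound 3, and a limit rather than a number seems the likeliest outcome. Compound 3 is estimated at 40000 nM, within a range from 20000 nM to 100000 nM. The expected step of a number no higher from compound 2 to compound 3 (the limit leaves the size open) is thus essentially none.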

Compound 3, half-maximal inhibitory concentration: > 40000 nM
Compound 3 gave a limit, no number; the forecaster's own chance of this, stated with the estimate: 85%; the middle value sits exactly at the limit.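

In this assay compound 3 gives > 40000 nM, which is a limit and not a number. Compound 2 also gives a limit, so no step can be read from compound 2 to compound 3. The compounds shown leave open whether acetamido in place of 4-(1-methyl-1H-imidazol-5-yl)-1H-1,2,3-triazol-1-yl changes inhibition at all, as all of them sit at one edge: the limit of > 40000 nM in this assay, at which 3 of the 3 values shown sit.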